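The compounds below may be only part of what the source reports. "The series", "measured", "known", "first", "only" and "open" are said of these compounds alone.

Working notes on the series. In an ADME assay on BJ cells (Homo sapiens) for cytotoxicity, read by CellTiter-Glo, with a stated time of 72 h (a higher number here means that more compound is needed for the effect, a lower number that less compound is needed), compound 1 `C/C1=C/[C@]23O[C@H]2[C@H](C)C=C3C(=O)[C@@](C)(O)C(=O)CC(C)(C)/C=C/C1=O` gives 26000 nM, compound 2 `C=C1/C=C/C(C)(C)CC2=C(C)C(=O)[C@]3(C[C@@H](C)C=C3/C=C\1C)O2` gives 26000 nM and compound 3 `C/C1=C/C2=C[C@H](C)C[C@@]23O[C@]2(CC(C)(C)C[C@@H]2[C@@]1(O)C(F)(F)F)[C@@H](C)C3=O` gives 26000 nM. Compound 3 therefore stands level with compounds 1 and 2, and the three differ only within the scatter. Among the compounds with values here, no two of these measured compounds differ in one place, so the data show no single-change step. Compound 4 `C/C1=C/C2=C[C@H](C)C[C@@]23O[C@]2(CC(C)(C)C[C@@H]2[C@@]1(O)C#N)[C@@H](C)C3=O` departs from compound 3 by cyano in place of trifluoromethyl on a saturated ring carbon, with cyano in place of trifluoromethyl on a saturated ring carbon. Within the data shown here, with no measured step to suggest otherwise, the change is expected to leave this assay without a shift beyond the scatter, in either direction. The expected step of a 1.0-fold lower number from compound 3 to compound 4 (0.02 log units; within the scatter) is correspondingly small. For compound 4 the estimated value is 25000 nM, with an expected range of 10000 nM to 30000 nM.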

Compound 4, half-maximal effective concentration: 26000 nM
For compound 4 the middle estimate is 1.0-fold (0.02 log units) below the measured one; the range from low to high includes it.
By their numbers in this assay, from the lowest: compounds 1, 2, 3 and 4 (each within the scatter of the next).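

Within the data shown here, this is the first single-change step: in this assay, cyano in place of trifluoromethyl on a saturated ring carbon brings no change at the digits printed from compound 3 to compound 4 (within the scatter). At this position, the read-out therefore tolerates the exchange of four heavy atoms for two and the entry of one hydrogen-bond acceptor without a shift beyond the scatter. No supporting data bear on why the read-out holds here. From the compounds shown here alone, whether an amine or a carboxylic acid on this saturated ring carbon would leave the read-out equally flat stays open.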